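Urea series on a shared core: cytotoxicity in human kidney cells

A few compounds are considered here, and "the series" means these few. Any claim that something is new, unique, unknown or untested is made for them only; others in the source may bear on it.

Compound 1 `Cc1cc(NC(=O)Nc2ccccc2C(F)(F)F)c2ccccc2n1` gives > 25000 nM in an ADME assay on HEK293 cells (Homo sapiens) for cytotoxicity, with a stated time of 72 h; a higher number here means that more compound is needed for the effect, a lower number that less compound is needed; that value is a limit of the assay.
Compound 2 `Cc1cc(NC(=O)Nc2ccc(N)cc2)c2ccccc2n1` gives > 25000 nM in this assay, again a limit.
Compound 3 `Cc1cc(NC(=O)Nc2ccc(O)cc2)c2ccccc2n1` gives > 25000 nM in this assay, also a limit.

Every value shown is a limit rather than a number, as the limit of > 25000 nM in this assay, at which 3 of the 3 values shown sit, records, so compound 3 stands at that limit together with the other two. Going by the values given here, the only step between measured compounds, a step that the two limits leave unreadable from compound 2 to compound 3, cannot be read for size. Compound 4 `Cc1cc(NC(=O)Nc2ccccc2N)c2ccccc2n1` differs from compound 3 by 2-aminophenyl in place of 4-hydroxyphenyl on an amide-type nitrogen. No readable step bears on this change, so no shift beyond the scatter can be foreseen, and compound 4 is expected to sit at the same limit, with an estimated step that the limit leaves unreadable from compound 3 to compound 4. Compound 4 is therefore estimated at 40000 nM, between 20000 nM and 100000 nM.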

Compound 4, half-maximal effective concentration: > 25000 nM
Compound 4 ended at the assay's limit; the forecaster's own chance of this, stated with the estimate: 85%; the middle value does not contradict the limit.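

Compound 4 joins compounds 1, 2 and 3 at a limit, so none of the steps between these compounds can be read: the limit of > 25000 nM in this assay, at which 4 of the 4 values shown sit.

The compounds shown leave open what concentration of any of them produces the effect in this assay.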